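A few compounds are considered here, and "the series" means these few. Any claim that something is new, unique, unknown or untested is made for them only; others in the source may bear on it.

In a functional assay on MDA-MB-231 cells (Homo sapiens) for inhibition, read by sulforhodamine B assay, with a stated time of 48 h, tested at 10 uM (a lower number here means less inhibition of growth, a higher number more inhibition of growth at the concentration tested), compound 2 (`Clc1ccc(-c2cn3nc(-c4ccccc4)nc3s2)cc1`) gives 57% and so sits within the scatter of compound 1 (`COc1ccc(-c2nc3sc(-c4ccccc4)cn3n2)cc1`) at 53% and well under compound 3 (`COc1ccc(-c2nc3sc(-c4ccc(Cl)cc4)cn3n2)cc1`) with 86.7% in that read-out. Compound 4 (`c1ccc(-c2nc3sc(-c4ccccc4)cn3n2)cc1`) differs from compound 2 by one swap (hydrogen in place of chloro on an aromatic carbon) that puts hydrogen in place of chloro on an aromatic carbon. The closest measured precedent is the reverse swap, seen in a large rise (a number 33.7 percentage points higher from compound 1 to compound 3 (beyond the scatter)) beyond the scatter. That rise was measured with methoxy present, which compound 4 lacks, and adding methoxy gave a modest rise (a number 29.7 percentage points higher from compound 2 to compound 3 (beyond the scatter)) also beyond the scatter, so the precedent transfers only loosely. A fall of similar size is therefore expected in this assay as an estimated step (a number 30 percentage points lower from compound 2 to compound 4 (beyond the scatter)) beyond the scatter. Compound 4 is expected at 27% within a range of 10% to 46% in this estimate.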

Compound 4, percent growth inhibition at one concentration: 35%
The estimate for compound 4 lay 8 percentage points below the measured number; the measured number falls inside the stated range.
By their numbers in this assay, from the lowest: compound 4; then compounds 1 and 2 (each within the scatter of the next); then compound 3.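

In this assay, hydrogen in place of chloro lowers growth inhibition even with no methoxy in the molecule, giving a number 22 percentage points lower from compound 2 to compound 4 (beyond the scatter). The rise that chloro brings at this position therefore does not depend on methoxy, and it appears on both cores: the same change on two cores in this assay, a number 33.7 percentage points higher (beyond the scatter) from compound 1 to compound 3 and a number 22 percentage points higher (beyond the scatter) from compound 4 to compound 2, 11.7 percentage points apart, within the scatter of two such steps. Methoxy shows the same independence from chloro, with hydrogen in its place giving a number 18 percentage points lower from compound 1 to compound 4 (beyond the scatter), and again the change holds on two cores: the same change on two cores in this assay, a number 29.7 percentage points higher (beyond the scatter) from compound 2 to compound 3 and a number 18 percentage points higher (beyond the scatter) from compound 4 to compound 1, 11.7 percentage points apart, within the scatter of two such steps.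

The compounds shown leave open whether an amine or a carboxylic acid in place of the chloro would keep this rise. They also leave open how the four compounds would compare at any other concentration.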